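This account rests on a few compounds, and the source may have more. Where it says the series, first, only, none or still open, it means among the compounds named here.

Measured so far:
Compound 1 `Nc1nc(O)c2c(n1)n(C1OC(CO)[C@@H](O)[C@H]1O)c(=O)n2CC(O)CO` – in a functional assay (B cells) with Mus musculus as the target (on this read-out higher numbers stand for an effect only at larger amounts of compound and lower numbers for an effect already at smaller amounts), compound 1 gives 45 uM.
Compound 2 `Nc1nc(O)c2c(n1)n(C1OC(CO)[C@@H](O)[C@H]1O)c(=O)n2Cc1ccc([N+](=O)[O-])cc1` – in this assay compound 2 gives 40 uM.

Going by the values given here, compound 2 has the lower of the two numbers, yet the only measured step, a 1.1-fold lower number from compound 1 to compound 2 (0.05 log units; within the scatter), lies within the scatter, so the two compounds are indistinguishable here. Compound 3 `NCC(O)Cn1c(=O)n(C2OC(CO)[C@@H](O)[C@H]2O)c2nc(N)nc(O)c21` differs from compound 2 by 2-amino-1-hydroxyethyl in place of 4-nitrophenyl on a saturated chain carbon bound to an aromatic nitrogen. That step bears on the new one, since it exchanged a group at the same place and left the number unchanged, and the entering group resembles the group of compound 1. No step beyond the scatter is therefore expected. Compound 3 is estimated at 42 uM in this assay, ranging from 18 uM to 100 uM. The expected step of a 1.1-fold higher number from compound 2 to compound 3 (0.02 log units; within the scatter) stays within the scatter.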

Compound 3, concentration for half-maximal effect: 28 uM
Compound 3: middle estimate off by 1.5-fold (0.18 log units), on the high side; measured number inside the range.
By their numbers in this assay, from the lowest: compounds 3, 2 and 1 (each within the scatter of the next).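

In this assay, 3-amino-2-hydroxypropyl in place of 4-nitrobenzyl gives a 1.4-fold lower number from compound 2 to compound 3 (0.15 log units; within the scatter), so at this position a chain with no ring and a group with an aromatic ring cannot be told apart. Amino in place of hydroxy on the chain gives a 1.6-fold lower number from compound 1 to compound 3 (0.21 log units; within the scatter), so this smaller exchange cannot be told apart either. The compounds shown leave open whether a carboxylic acid on the chain, or a longer chain, would give a step beyond the scatter. No measurement at hand offers an explanation for these results.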